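Ethyl to isopropyl on the ring nitrogen of compound 3

This account rests on a few compounds, and the source may have more. Where it says the series, first, only, none or still open, it means among the compounds named here.

Measured so far:
compound 1, `COc1cc(C(=O)NS(=O)(=O)c2ccccc2C)ccc1Cc1cn(C)c2ccc(C(=O)NCC3CCCC3)cc12`, gives 8.4
compound 2, `CCC(CC)CNC(=O)c1ccc2c(C)cn(Cc3ccc(C(=O)NS(=O)(=O)c4ccccc4Br)cc3OC)c2c1`, gives 9.1
compound 3, `CCC(CC)CNC(=O)c1ccc2c(c1)c(Cc1ccc(C(=O)NS(=O)(=O)c3ccccc3C)cc1OC)cn2CC`, gives 9.5

All three values come from an assay on isolated protein for binding affinity to cysteinyl leukotriene receptor 1 (Cavia porcellus); a higher number here means a more potent compound, by a factor of ten per unit of this negative logarithm, a lower number a less potent compound. Compound 3 gives the highest number of the three. Its nearest neighbour is compound 2, which lies lower by an amount beyond the usual scatter, and compound 1 lies furthest below it, again beyond the scatter. Among the compounds with values here, compounds 1 and 3 both carry a short chain on the aromatic nitrogen of the shared core, but they differ elsewhere as well, so no single step between them can be read off.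

Compound 4, `CCC(CC)CNC(=O)c1ccc2c(c1)c(Cc1ccc(C(=O)NS(=O)(=O)c3ccccc3C)cc1OC)cn2C(C)C`, has not been measured. It differs from compound 3 in one place: methyl in place of hydrogen on a saturated chain carbon bound to an aromatic nitrogen and a saturated chain carbon. Seen one bond further out, this is an ethyl becoming an isopropyl. Within the data shown here, nothing among the measured compounds isolates a change of this kind, so there is no measured step to lean on. Adding a methyl to a chain that already sits on this nitrogen is expected to move the value little, and no step beyond the scatter is expected in either direction. The step this implies is expected to be a number 0.10 log units lower from compound 3 to compound 4 (within the scatter). Compound 4 is therefore estimated at 9.4, with a range from 8.9 to 9.9.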

Compound 4, negative logarithm of the antagonist equilibrium constant: 8.8
Estimate against measurement, compound 4: 0.60 log units above; the whole stated range lies above it.
By their numbers in this assay, from the lowest: compound 1; then compounds 4 and 2 (each within the scatter of the next); then compound 3.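

In this assay, within the data shown here, turning the ethyl on the aromatic nitrogen into an isopropyl gives a number 0.70 log units lower from compound 3 to compound 4 (beyond the scatter), the first change in this set that can be read on its own, with everything else in the molecule held fixed. It shows that this position is not indifferent to its substituent: methyl in place of hydrogen on the saturated chain carbon bound to the aromatic nitrogen is enough to lower the number by more than repeated measurements would scatter, even though only one carbon has been added. Nothing measured here accounts for the drop, so the result records its size and direction but gives no reason for it.

Among these compounds, with only this pair, it remains open whether a straight propyl chain, a cyclopropyl ring or a tert-butyl group on the same nitrogen would sit nearer to the ethyl compound or to the isopropyl compound. From the compounds shown here alone, it also remains open whether the same methyl would lower the number by a similar amount if the bromine-bearing sulfonamide ring of compound 2 or the cyclopentylmethyl amide of compound 1 were present.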